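The source may report more compounds than this note shows. Statements on the series, on what has been measured and on what is new or still open speak of the compounds shown alone.

Measured in a functional assay on BaF3 cells (Mus musculus) for inhibition, read by MTT assay, with a stated time of 3 days; a higher number here means a weaker inhibitor of growth, a lower number a stronger inhibitor of growth:
- Compound 1 `O=C(Nc1ccc(Cl)cc1)Nc1ccc(Nc2ncnc3c2OCCN3)cc1`: > 10000 nM
- Compound 2 `COc1cccc(NC(=O)Nc2ccc(Nc3ncnc4c3OCCN4)cc2)c1`: > 10000 nM
- Compound 3 `Cc1ccc(F)c(NC(=O)Nc2ccc(Nc3ncnc4c3OCCN4)cc2)c1`: > 10000 nM

Each of these entries is a limit of the assay and not a number. Compound 3 therefore stands at a limit only: > 10000 nM. It has no numerical position in the series, and the limit of > 10000 nM in this assay, at which 3 of the 3 values shown sit, sums up the whole set so far.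

The next change leads to compound 4 `O=C(Nc1ccc(Nc2ncnc3c2OCCN3)cc1)Nc1cccs1`, with thiophen-2-yl in place of 2-fluoro-5-methylphenyl on an amide-type nitrogen.

Three measured steps are swaps at this same place, and none has a readable size: a step that the two limits leave unreadable from compound 1 to compound 2, a step that the two limits leave unreadable from compound 1 to compound 3 and a step that the two limits leave unreadable from compound 2 to compound 3. They give no direction and no magnitude to carry over. For the measured compounds named here, no measured compound has a five-membered aromatic ring at this place, so the new group is untested here.

No step beyond the scatter is expected in this assay because the limit of > 10000 nM in this assay, at which 3 of the 3 values shown sit, is all that the series shows. The step expected is a number no higher from compound 3 to compound 4 (the limit leaves the size open), an estimate with no direction favoured. The most likely outcome is another limit rather than a number. Compound 4 is estimated at 10000 nM, with an expected range from 3000 nM to 30000 nM.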

Compound 4, concentration for 50% growth inhibition: > 10000 nM
Compound 4: a limit, no number; the forecaster's own chance of this, stated with the estimate: 85%; the middle value sits exactly at the limit.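

In this assay compound 4 gives > 10000 nM, a limit of the assay and not a number. Its steps to compound 1, compound 2 and compound 3 cannot be read, and the series still rests on one entry: the limit of > 10000 nM in this assay, at which 4 of the 4 values shown sit. The compounds shown leave open which group on this amide-type nitrogen, if any, would give a numerical value.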